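A few compounds are considered here, and "the series" means these few. Any claim that something is new, unique, unknown or untested is made for them only; others in the source may bear on it.

Measured so far in a functional assay on OVCAR-5 cells (Homo sapiens) for inhibition, with a stated time of 48 h, tested at 50 uM; a higher number here means more inhibition of growth at the concentration tested, a lower number less inhibition of growth:
compound 1 `C=C[C@@](C)(/C=C/c1ccc(OC(=O)CCC)cc1)CCC=C(C)C` gives 41%
compound 2 `C=C[C@@](C)(/C=C/c1ccc(OC(=O)CCCCCCCCCCCCCCC)cc1)CCC=C(C)C` gives 64%

Compound 1 at 41% is the lower of the two numbers. Compound 3 `C=C[C@@](C)(/C=C/c1ccc(OC)cc1)CCC=C(C)C` is not yet measured. Its difference from compound 1 is methyl in place of propylcarbonyl on an oxygen on an aromatic ring that is, methyl in place of propylcarbonyl on an oxygen on an aromatic ring.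

Within the data shown here, the only measured step is a number 23 percentage points higher from compound 1 to compound 2 (beyond the scatter) and it comes with dodecyl in place of hydrogen on a saturated chain carbon. That change keeps the carbonyl, which compound 3 lacks, so it is a loose guide and sets no pattern. Taken in reverse, it suggests a small downward step in this assay that may not clear the scatter. The expected step is a number 8 percentage points lower from compound 1 to compound 3 (within the scatter) as an estimate. For compound 3 the estimated value is 33% with an expected range of 14% to 54% around it.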

Compound 3, percent growth inhibition at one concentration: 37%
Beside the measured number, compound 3's estimate is 4 percentage points below it; measured number inside the range.
By their numbers in this assay, from the lowest: compounds 3 and 1 (each within the scatter of the next); then compound 2.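

Swapping propylcarbonyl for methyl on the oxygen on the aromatic ring, in this assay, gives a number 4 percentage points lower from compound 1 to compound 3 (within the scatter) and so removes the carbonyl with no change beyond the scatter. The earlier step, a number 23 percentage points higher from compound 1 to compound 2 (beyond the scatter), altered only the chain and kept the carbonyl, so it could not show this. In this pair, the carbonyl and the propyl chain can be lost together without a readable change in growth inhibition at the concentration tested, and no measurement available here bears on the reason.

On these data alone, it remains open whether the higher number of compound 2 needs the carbonyl, which a long alkyl ether such as hexadecyl on the same oxygen would test. As far as these compounds go, it is also open how a free hydroxyl or an acetyl group at this oxygen would read in this assay.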